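The compounds below may be only part of what the source reports. "The series", "measured", "known", "first", "only" and "open" are said of these compounds alone.

The measured compounds:

Compound 1 `COc1ccc(/C=C/C(=O)c2ccc(OC)c3c2OC(C)(C)C=C3)cc1O`: in an ADME assay on L02 cells (Homo sapiens) for cytotoxicity, read by MTT assay (a higher number here means a weaker inhibitor, a lower number a stronger inhibitor), compound 1 gives > 10000 nM, which is a limit of the assay and not a number.
Compound 2 `C#CCOc1cc(/C=C/C(=O)c2ccc(OC)c3c2OC(C)(C)C=C3)ccc1OC`: in this assay compound 2 gives > 10000 nM, also a limit.
Compound 3 `C=CCOc1cc(/C=C/C(=O)c2ccc(OC)c3c2OC(C)(C)C=C3)ccc1OC`: in this assay compound 3 gives > 20000 nM, again a limit.

Compound 3 therefore stands at a limit, and the two other values shown are limits as well, so none of the three can be placed above or below another. Compound 4 `CCC(=O)Oc1cc(/C=C/C(=O)c2ccc(OC)c3c2OC(C)(C)C=C3)ccc1OC` is the unmeasured compound. The steps that would bear on the change made there are a step that the two limits leave unreadable from compound 1 to compound 3 and a step that the two limits leave unreadable from compound 2 to compound 3, both changes on the same oxygen on an aromatic ring; both are left unreadable because the limit of > 10000 nM in this assay, at which 2 of the 3 values shown sit, and (the limit of > 20000 nM in this assay, at which 1 of the 3 values shown sits). The new change is propanoyl in place of allyl on an oxygen on an aromatic ring.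

With every value a limit, no direction and no size of step can be read from the measured compounds. The estimate for the step from compound 3 to compound 4 is thus a number no higher from compound 3 to compound 4 (the limit leaves the size open), meaning no step beyond the scatter is expected. Compound 4 is expected to give 20000 nM in this assay, estimated between 8000 nM and 60000 nM, most likely again reported as a limit.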

Compound 4, half-maximal inhibitory concentration: > 10000 nM
Compound 4: only a limit was reported; the forecaster's own chance of this, stated with the estimate: 85%; the middle value is on the limit's open side.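

In this assay compound 4 gives > 10000 nM, which is a limit of the assay and not a number. Within the data shown here, no step from compound 1, compound 2 or compound 3 to compound 4 can be read, because all four values are limits: the limit of > 10000 nM in this assay, at which 3 of the 4 values shown sit. The fourth value stands at a separate limit: the limit of > 20000 nM in this assay, at which 1 of the 4 values shown sits. The compounds shown leave open whether propanoyl, allyl, propargyl or hydrogen on this oxygen makes any difference to the read-out.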